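This account rests on a few compounds, and the source may have more. Where it says the series, first, only, none or still open, it means among the compounds named here.

The series shares one core and varies only the amide-linked aryl ring. Compound 1 `O=C(CSc1nc(Nc2ccccc2)c2ccccc2n1)Nc1cccc(F)c1` gives 15600 nM in a functional assay on PC-3 cells (Homo sapiens) for inhibition, read by MTT assay, with a stated time of 72 h; on this read-out lower numbers stand for stronger inhibition and higher numbers for weaker inhibition. Compound 2 `O=C(CSc1nc(Nc2ccccc2)c2ccccc2n1)Nc1cccc(Cl)c1` gives 12600 nM in this assay, and compound 3 `O=C(CSc1nc(Nc2ccccc2)c2ccccc2n1)Nc1ccc(Cl)c(Cl)c1` gives 12100 nM in this assay. The change from compound 2 to compound 1 is fluoro in place of chloro on an aromatic carbon and gave a 1.2-fold higher number from compound 2 to compound 1 (0.09 log units; within the scatter). Compound 3 differs from compound 2 by chloro in place of hydrogen on an aromatic carbon, and that step was a 1.0-fold lower number from compound 2 to compound 3 (0.02 log units; within the scatter); from compound 1 to compound 3 the step was a 1.3-fold lower number from compound 1 to compound 3 (0.11 log units; within the scatter). Compound 4 `O=C(CSc1nc(Nc2ccccc2)c2ccccc2n1)Nc1ccc(F)c(Cl)c1` is not yet measured. It differs from compound 3 by fluoro in place of chloro on an aromatic carbon, the same kind of change as that from compound 2 to compound 1, though the surroundings differ: in compound 1 the fluoro sits meta to a large group, whereas in compound 4 it sits ortho to a chloro group and para to a large group. Because the earlier step was a 1.2-fold higher number from compound 2 to compound 1 (0.09 log units; within the scatter), compound 4 is expected to show a step of about a 1.2-fold higher number from compound 3 to compound 4 (0.06 log units; within the scatter). Compound 4 is therefore estimated at 14000 nM, with a range from 7000 nM to 28000 nM.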

Compound 4, half-maximal inhibitory concentration: 15500 nM
For compound 4 the middle estimate is 1.1-fold (0.04 log units) below the measured one; the range from low to high includes it.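

In this assay, fluoro in place of chloro on an aromatic carbon gave a 1.3-fold higher number from compound 3 to compound 4 (0.11 log units; within the scatter), and this step agrees with the earlier case of the same change: the same change on two cores in this assay, a 1.2-fold higher number (0.09 log units; within the scatter) from compound 2 to compound 1 and a 1.3-fold higher number (0.11 log units; within the scatter) from compound 3 to compound 4, 1.0-fold (0.01 log units) apart, within the scatter of two such steps The other two steps to the new compound are also small, with a 1.2-fold higher number from compound 2 to compound 4 (0.09 log units; within the scatter) for fluoro in place of hydrogen and a 1.0-fold lower number from compound 1 to compound 4 (0.00 log units; within the scatter) for 3-chloro-4-fluorophenyl in place of 3-fluorophenyl. The change therefore carried across these two surroundings without any difference beyond the scatter, but with each step itself within the scatter, this does not show that the change has a real effect or that the agreement would hold on other cores.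

The compounds shown carry only fluoro and chloro on the amide-linked aryl ring, so it stays open whether an amine, a carboxylic acid or a methoxy group there would shift the number beyond the scatter. Also open, as far as these compounds go, is what a longer chain between the sulfur and the carbonyl would do.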